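The compounds below may be only part of what the source reports. "The series", "measured", "known", "first", "only" and "open" are said of these compounds alone.

Compound 1 `O=C(O)Cc1sc(C(c2ccc(F)cc2)c2ccc(F)cc2)nc1-c1ccnc(F)c1` gives 4.7 nM in an in vitro functional assay on HEK285-7 cells for antagonist activity at prostaglandin D2 receptor 2 (Homo sapiens), read by BRET and beta-arrestin recruitment (a higher number here means a weaker inhibitor, a lower number a stronger inhibitor), and compound 2 `O=C(O)Cc1sc(C(c2ccc(F)cc2)c2ccc(F)cc2)nc1-c1ccoc1` gives 130 nM, which is a 28-fold higher number from compound 1 to compound 2 (1.44 log units; beyond the scatter). Compound 3 `Cc1cc(-c2nc(C(c3ccc(F)cc3)c3ccc(F)cc3)sc2CC(=O)O)cnc1N` stands apart from both: in this assay compound 3 reaches only a limit, > 100000 nM, so that its place is the limit of > 100000 nM in this assay, at which 1 of the 3 values shown sits. The change to compound 4 `O=C(O)Cc1sc(C(c2ccc(F)cc2)c2ccc(F)cc2)nc1-c1ccc(Cl)cc1` is 4-chlorophenyl in place of 6-amino-5-methylpyridin-3-yl on an aromatic carbon. The measured steps that bear on it run the other way: an at least 21000-fold higher number from compound 1 to compound 3 (4.32 log units; beyond the scatter) and an at least 760-fold higher number from compound 2 to compound 3 (2.88 log units; beyond the scatter). Both single out the 6-amino-5-methylpyridin-3-yl group as the part that differs, and 4-chlorophenyl, like 2-fluoropyridin-4-yl and furan-3-yl, is an aromatic ring without that group. A large step down in this assay is therefore expected: an at least 3300-fold lower number from compound 3 to compound 4 (3.52 log units; beyond the scatter). Compound 4 is estimated at 30 nM, between 5 nM and 300 nM.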

Compound 4, half-maximal inhibitory concentration: 180 nM
Compound 4: the middle estimate sits 6.0-fold (0.78 log units) below what was measured; the range from low to high includes it.
By their numbers in this assay, from the lowest: compound 1; then compounds 2 and 4 (each within the scatter of the next). At a limit, above all of these: compound 3.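

A ring of carbon only is accepted at this position (an at least 550-fold lower number from compound 3 to compound 4 (2.74 log units; beyond the scatter)). Compound 3 remains a limit in this assay: the limit of > 100000 nM in this assay, at which 1 of the 4 values shown sits. Furan-3-yl and 4-chlorophenyl cannot be told apart here (a 1.4-fold higher number from compound 2 to compound 4 (0.14 log units; within the scatter)), while 2-fluoropyridin-4-yl keeps a clear lead (a 38-fold higher number from compound 1 to compound 4 (1.58 log units; beyond the scatter)).

Going by these compounds, it stays open whether the amine or the methyl of the 6-amino-5-methylpyridin-3-yl group accounts for the loss in compound 3. On these data alone, it also stays open whether the fluorine or the ring nitrogen of 2-fluoropyridin-4-yl accounts for the lead of compound 1.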